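Swapping a fluorophenyl for a pyridyl in an acylguanidine agonist

The compounds below may be only part of what the source reports. "The series", "measured", "known", "first", "only" and "open" are said of these compounds alone.

Compound 1 `N=C(NCCCc1c[nH]cn1)NC(=O)CC(c1ccc(F)cc1)c1ccc(F)cc1`: 204 nM
Compound 2 `N=C(NCCCc1c[nH]cn1)NC(=O)CC(c1ccccc1)c1ccc(F)cc1`: 55 nM

In a functional assay on cardiac atrium for agonist activity at histamine H2 receptor (Cavia porcellus) (on this read-out lower numbers stand for an effect already at smaller amounts and higher numbers for an effect only at larger amounts of compound), compound 2 gives 55 nM, the lowest of the two numbers; its nearest neighbour is compound 1, whose step a 3.7-fold lower number from compound 1 to compound 2 (0.57 log units; beyond the scatter) came from replacing fluoro by hydrogen. Compound 3 `N=C(NCCCc1c[nH]cn1)NC(=O)CC(c1ccccc1)c1ccccn1` carries a different change: pyridin-2-yl in place of 4-fluorophenyl on a saturated chain carbon bound to an aromatic carbon and a saturated chain carbon. Among the measured compounds shown here, no measured step covers this exchange; the only step known concerns a fluorine, so it gives limited guidance. A step of roughly a 1.8-fold lower number from compound 2 to compound 3 (0.26 log units; within the scatter) is expected, leaning toward a lower number. For compound 3 the estimate is 30 nM, within 8 nM to 120 nM.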

Compound 3, half-maximal effective concentration: 51.3 nM
Beside the measured number, compound 3's estimate is 1.7-fold (0.23 log units) below it, within the range that was stated.
By their numbers in this assay, from the lowest: compounds 3 and 2 (each within the scatter of the next); then compound 1.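

In this assay, pyridin-2-yl can stand in place of 4-fluorophenyl on this saturated chain carbon, with a 1.1-fold lower number from compound 2 to compound 3 (0.03 log units; within the scatter), so a whole ring can be exchanged here for one holding a hydrogen-bond acceptor without a shift beyond the scatter. The earlier compounds shown here showed only that a single fluoro on a ring can matter at this carbon. No measurement shown accounts for the two rings reading alike.

As far as these compounds go, whether pyridin-3-yl, pyridin-4-yl or cyclohexyl would fare the same at this carbon stays open. So does whether the exchange holds when the remaining phenyl carries a fluoro.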